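The source may report more compounds than this note shows. Statements on the series, on what has been measured and on what is new or still open speak of the compounds shown alone.

Working notes on the series

In a functional assay on HT-29 cells (Homo sapiens) for inhibition, read by sulforhodamine B assay, with a stated time of 48 h (a lower number here means a stronger inhibitor of growth, a higher number a weaker inhibitor of growth), compound 2 `COc1c(O)ccc(/C=C/C2(C)C=CC(=O)O2)c1OC` gives 19100 nM. Its methylated counterpart, compound 1 `COc1ccc(/C=C/C2(C)C=CC(=O)O2)c(OC)c1OC`, gives 133000 nM in this assay. The step between them, a 7.0-fold higher number from compound 2 to compound 1 (0.84 log units; beyond the scatter), rests on one change:

methyl in place of hydrogen on an oxygen on an aromatic ring

Compound 3 `CC1(/C=C/c2cccc(O)c2)C=CC(=O)O1` gives 97400 nM in this assay; its value lies close to that of compound 1 and well apart from that of compound 2. The difference between the core of compound 3 and the core of compound 2 is not broken down here.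

Compound 4 `COc1cccc(/C=C/C2(C)C=CC(=O)O2)c1` has not yet been measured in this assay. It differs from compound 3 by:

methyl in place of hydrogen on an oxygen on an aromatic ring

The place of this change reads the same as for the change from compound 2 to compound 1, so the two are taken as the same change. On that single precedent, a step towards a weaker inhibitor of growth is expected, a 4.1-fold higher number from compound 3 to compound 4 (0.61 log units; beyond the scatter), resting on a 7.0-fold higher number from compound 2 to compound 1 (0.84 log units; beyond the scatter). For compound 4 the estimated value in this assay is 400000 nM, expected between 120000 nM and 1500000 nM, with some chance that so weak an inhibitor of growth returns only a limit.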

Compound 4, concentration for total growth inhibition: 17000 nM
Compound 4: middle estimate off by 24-fold (1.37 log units), on the high side; the whole stated range lies above it.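

In this assay, the change from hydroxy to methoxy gives a 5.7-fold lower number from compound 3 to compound 4 (0.76 log units; beyond the scatter), so the direction seen on the earlier pair does not carry over to this core. Set side by side, the same change moves the number in opposite directions on the two cores, and the gap between the steps is larger than scatter alone would explain: the same change on two cores in this assay, a 7.0-fold higher number (0.84 log units; beyond the scatter) from compound 2 to compound 1 and a 5.7-fold lower number (0.76 log units; beyond the scatter) from compound 3 to compound 4, 40-fold (1.60 log units) apart, beyond the scatter of two such steps. Within these four compounds, the outcome of this change depends on the core, so one pair cannot be used to predict the other; with only two pairs, however, this does not show which feature of the cores is responsible or how the change would behave on a further core.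

From the compounds shown here alone, it remains open whether a longer chain on the same oxygen, such as ethoxy in place of methoxy, would follow the step seen on the core of compound 2 or the one seen on the core of compound 3. Going by these compounds, it is equally open how an amine in place of the hydroxy would behave on either core.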